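Swapping a phenolic hydroxy for methyl in a hydroxyguanidine hydrazone

The source may hold more compounds than are shown below. What is called first, only, known or untested is meant among the compounds shown, and "the series" means these compounds.

The series is built around an amidinohydrazone bearing a hydroxyl on the guanidine unit, joined to a benzylidene. Compound 1 `N=C(NO)N/N=C/c1ccc(O)cc1` carries a hydroxy group on the aromatic ring. In a functional assay on HL-60 cells (Homo sapiens) for antiproliferative activity (a higher number here means a weaker inhibitor, a lower number a stronger inhibitor), compound 1 gives only a limit, > 100000 nM, not a measured number. Its reading sits at the limit of > 100000 nM in this assay, at which 1 of the 2 values shown sits, so where compound 1 truly stands among the numbers shown cannot be fixed; all that is known is that it is a weak inhibitor. The second measured member, compound 2 `N=C(NO)N/N=C/c1ccccc1Cl`, has a chlorine on the ring instead and in this assay gives 60000 nM, a number rather than a limit. Within the data shown here, no single-point step between compound 1 and compound 2 is defined, so their two values are simply set side by side.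

Compound 3 `Cc1ccc(/C=N/NC(=N)NO)cc1` is the next member: methyl in place of hydroxy on an aromatic carbon. Compound 3 has not been measured. With compound 1 known only as a limit, the step from compound 1 to compound 3 is expected at an at least 1.2-fold lower number from compound 1 to compound 3 (0.09 log units; that floor lies within the scatter), toward a somewhat stronger inhibitor but with little confidence. Compound 3 is thus estimated at 80000 nM in this assay, within a range from 30000 nM to 200000 nM.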

Compound 3, half-maximal inhibitory concentration: 67000 nM
Compound 3: the middle estimate sits 1.2-fold (0.08 log units) above what was measured; measured number inside the range.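

Methyl in place of hydroxy on this aromatic carbon, para to a group of 7 heavy atoms, gives the first comparison at this position that has a measured number on one side. In this assay the change amounts to an at least 1.4-fold lower number from compound 1 to compound 3 (0.17 log units; that floor lies within the scatter). This is a floor and not a size, so the exchange is compatible with almost no change as well as with a larger gain, and the true step has no upper bound because compound 1 is known only as a limit: the limit of > 100000 nM in this assay, at which 1 of the 3 values shown sits.

The compounds shown leave open how other groups on this same aromatic carbon would read, such as an amine, a methoxy group, a carboxylic acid or a longer alkyl chain, and so whether any substituent here can move the number clearly beyond the scatter. They also leave open whether methyl would behave the same way elsewhere on the ring, since compound 2 differs from compound 3 in more than one place and offers no direct comparison.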